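Ester tail swap: from hexyl to trichloroethyl

A few compounds are considered here, and "the series" means these few. Any claim that something is new, unique, unknown or untested is made for them only; others in the source may bear on it.

Measured so far:
compound 1, `CCCOC(=O)/C=C/c1ccc(NC(=O)C2(NC(=O)c3ccc4c(C5CCCC5)c(-c5ncc(Cl)cn5)n(C)c4c3)CCC2)cc1OCC`, 0.35 h
compound 2, `CCCCCCOC(=O)/C=C/c1ccc(NC(=O)C2(NC(=O)c3ccc4c(C5CCCC5)c(-c5ncc(Cl)cn5)n(C)c4c3)CCC2)cc1OCC`, 12.7 h

Both compounds were measured in an ADME assay (liver) for pharmacokinetics, with Liver microsome (Rattus norvegicus) as the target, using microsomes; on this read-out lower numbers stand for a shorter-lived compound and higher numbers for a longer-lived compound. Among the two numbers, compound 2 holds the higher one; the step of a 36-fold higher number from compound 1 to compound 2 (1.56 log units; beyond the scatter) separates it from compound 1. The change that leads to compound 3, `CCOc1cc(NC(=O)C2(NC(=O)c3ccc4c(C5CCCC5)c(-c5ncc(Cl)cn5)n(C)c4c3)CCC2)ccc1/C=C/C(=O)OCC(Cl)(Cl)Cl`, is trichloromethyl in place of pentyl on a saturated chain carbon bound to an oxygen next to a carbonyl group. Going by the values given here, the only measured step, from compound 1 to compound 2, concerned lengthening of the same chain and was large, so that read-out is clearly sensitive to what sits at this end of the molecule. Among the compounds with values here, the new change cuts the chain back while bringing in three chlorines, which no measured pair covers directly. Judged only by the shortened chain, a drop from compound 2 is expected, of the size a 6.4-fold lower number from compound 2 to compound 3 (0.80 log units; beyond the scatter). Compound 3 is therefore estimated at 2 h, with a range from 0.4 h to 10 h.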

Compound 3, half-life: 0.233 h
Estimate against measurement, compound 3: 8.6-fold (0.93 log units) above; measured number outside the range, below it.
By their numbers in this assay, from the lowest: compounds 3 and 1 (each within the scatter of the next); then compound 2.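

In this assay, replacing the hexyl tail with 2,2,2-trichloroethyl gives a 55-fold lower number from compound 2 to compound 3 (1.74 log units; beyond the scatter), so the high number of the hexyl ester does not carry over to this tail. Set against the propyl ester, the same tail gives a 1.5-fold lower number from compound 1 to compound 3 (0.18 log units; within the scatter), which places compound 1 and compound 3 together and leaves compound 2 alone at the top of these three, even though the tails of compound 1 and compound 3 differ in their atoms. Nothing available here explains why this position responds so strongly to the hexyl chain.

Three compounds cannot show whether the number climbs gradually or jumps somewhere between propyl and hexyl, and a butyl ester would fall within that gap. From the compounds shown here alone, it also remains open how an octyl ester, or a carboxylic acid in place of the ester, would behave in this assay.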